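Chloro for cyano: from compound 2 to compound 3

The source may report more compounds than this note shows. Statements on the series, on what has been measured and on what is new or still open speak of the compounds shown alone.

compound 1 `N#Cc1ccc(NC(=O)c2ccc3cccnc3c2O)cc1`: 180 nM
compound 2 `N#Cc1ccc(NC(=O)c2ccc3cccnc3c2O)c(C#N)c1`: 270 nM

Both compounds were measured in a functional assay on Jurkat cells (Homo sapiens) for cytotoxicity, read by luminescence and CellTiter-Glo, with a stated time of 3 days; a lower number here means a stronger inhibitor, a higher number a weaker inhibitor. Compound 2 gives 270 nM, which lies within the scatter of compound 1 at 180 nM. Compound 3 `N#Cc1ccc(NC(=O)c2ccc3cccnc3c2O)c(Cl)c1` has chloro in place of cyano on an aromatic carbon. Among the measured compounds shown here, only one measured step bears on this change, the one that put cyano in place of hydrogen on that same carbon: a 1.5-fold higher number from compound 1 to compound 2 (0.18 log units; within the scatter). That step stayed within the scatter, so no step beyond the scatter is expected in this assay. For the measured compounds named here, no measured compound here carries chloro, so this remains an expectation. The expected value for compound 3 is 200 nM, with an estimated range of 80 nM to 550 nM. This estimate amounts to an expected 1.4-fold lower number from compound 2 to compound 3 (0.13 log units; within the scatter).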

Compound 3, half-maximal inhibitory concentration: 550 nM
The estimate for compound 3 lay 2.8-fold (0.44 log units) below the measured number, and the stated range covers the measured number.
By their numbers in this assay, from the lowest: compounds 1 and 2 (each within the scatter of the next); then compound 3.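

In this assay, among the compounds shown here, chloro on this carbon gives the first change here that lies beyond the scatter (a 2.0-fold higher number from compound 2 to compound 3 (0.31 log units; beyond the scatter)). The same holds against hydrogen (a 3.1-fold higher number from compound 1 to compound 3 (0.49 log units; beyond the scatter)), whereas cyano on this carbon stayed within the scatter of hydrogen, so this position does not accept every replacement for hydrogen equally. Nothing available here accounts for the difference between chloro and cyano.

With only hydrogen, cyano and chloro shown on this carbon, no trend across groups can be drawn. As far as these compounds go, how fluoro, an amine or a carboxylic acid would behave here remains open.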